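Terminal amine swap on the propoxy chain

The source may hold more compounds than are shown below. What is called first, only, known or untested is meant among the compounds shown, and "the series" means these compounds.

The series shares one core, carried by compound 1 `COc1cc2c(Oc3ccc(NC(=O)c4cc(-c5ccccc5F)ccn4)cc3F)ccnc2cc1OCCCN1CCCCC1` and compound 2 `COc1cc2c(Oc3ccc(NC(=O)c4cc(-c5ccc(C(F)(F)F)cc5)ccn4)cc3F)ccnc2cc1OCCCN1CCCCC1`. In a functional assay on MKN-45 cells (Homo sapiens) for cytotoxicity, read by MTT assay, with a stated time of 72 h (a lower number here means a stronger inhibitor, a higher number a weaker inhibitor), compound 1 gives 180 nM and compound 2 gives 870 nM. Within the data shown here, the single measured step is a 4.8-fold higher number from compound 1 to compound 2 (0.68 log units; beyond the scatter), which leaves compound 2 with the higher of the two numbers so far, its only neighbour being compound 1.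

Compound 3 `COc1cc2c(Oc3ccc(NC(=O)c4cc(-c5ccc(C(F)(F)F)cc5)ccn4)cc3F)ccnc2cc1OCCCN1CCN(C)CC1` differs from compound 2 in 4-methylpiperazin-1-yl in place of piperidin-1-yl on a saturated chain carbon, three bonds along the chain from an oxygen on an aromatic ring. Among the measured compounds shown here, no measured step touches this end of the molecule: the one step in hand concerns the aryl group on the pyridine side and says nothing about the chain terminus. With no comparable change measured, no step beyond the scatter is expected in this assay, in either direction, and the expected step is no change at the digits printed from compound 2 to compound 3 (within the scatter), essentially flat, with a wide margin left for the unknown. Compound 3 is therefore estimated to give about 870 nM in this assay, with a range from 300 nM to 2500 nM.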

Compound 3, half-maximal inhibitory concentration: 330 nM
For compound 3 the middle estimate is 2.6-fold (0.42 log units) above the measured one; low and high end bracket the measured number.
By their numbers in this assay, from the lowest: compounds 1 and 3 (each within the scatter of the next); then compound 2.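

The chain terminus is not a silent position in this assay: 4-methylpiperazin-1-yl in place of piperidin-1-yl gives a 2.6-fold lower number from compound 2 to compound 3 (0.42 log units; beyond the scatter), so this end of the molecule moves the number, just as the aryl group does in a 4.8-fold higher number from compound 1 to compound 2 (0.68 log units; beyond the scatter). The step is read only with 4-(trifluoromethyl)phenyl in the molecule, so it describes this amine swap on one background and does not yet establish a general preference for 4-methylpiperazin-1-yl at the end of the chain. No supporting measurement bears on what in the swap produces the lower number, so the step stands as an observation without an explanation.

Still open, from the compounds shown here alone, is whether the step is tied to the methyl group or to the second ring nitrogen, which an unsubstituted piperazin-1-yl or a morpholin-4-yl at the same place would help to separate. Also open, going by these compounds, are whether 4-methylpiperazin-1-yl gives a step of similar direction with the 2-fluorophenyl group of compound 1, and whether a 2-(4-methylpiperazin-1-yl)ethyl chain or a longer chain keeps it.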